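A few compounds are considered here, and "the series" means these few. Any claim that something is new, unique, unknown or untested is made for them only; others in the source may bear on it.

Compound 1 `Cc1ccc(N/C(=N/O)c2ccc3occc3c2)cc1C` in an assay on tissue (HeLa cells) for inhibition of Indoleamine 2,3-dioxygenase 1 (Homo sapiens), read by spectrophotometry (a lower number here means a stronger inhibitor, a higher number a weaker inhibitor), gives > 30000 nM, which is a limit of the assay. Compound 2 `CC(=O)c1cccc(N/C(=N/O)c2ccc3occc3c2)c1` gives > 30000 nM, again a limit. Compound 3 `O=C(NCC1CCCCC1)c1cccc(N/C(=N/O)c2ccc3occc3c2)c1` gives > 30000 nM, also a limit.

Compound 3 thus has no number in this assay, only a limit, and it shares this with the other two compounds: the limit of > 30000 nM in this assay, at which 3 of the 3 values shown sit. Among the measured compounds shown here, the one measured step that touches it, a step that the two limits leave unreadable from compound 2 to compound 3, cannot be read either. Compound 4 `O=C(NCc1ccccc1)c1cccc(N/C(=N/O)c2ccc3occc3c2)c1` differs from compound 3 by phenyl in place of cyclohexyl on a saturated chain carbon bound to an amide-type nitrogen. For the measured compounds named here, no measured step bears on this change, and because of the limit of > 30000 nM in this assay, at which 3 of the 3 values shown sit, no direction can be read from the values at hand. The expected step, a number no higher from compound 3 to compound 4 (the limit leaves the size open), is therefore none beyond the scatter. Compound 4 is estimated at 30000 nM, within 10000 nM to 100000 nM, most likely again only a limit.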

Compound 4, half-maximal inhibitory concentration: > 30000 nM
Compound 4 ended at the assay's limit; the forecaster's own chance of this, stated with the estimate: 85%; the middle value sits exactly at the limit.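

Among the compounds shown here, no step among compound 2, compound 3 and compound 4 can be read, because each gives only a limit and no number: the limit of > 30000 nM in this assay, at which 4 of the 4 values shown sit. The compounds shown leave open whether any change to the shared core would give a readable number in this assay.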